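The compounds below may be only part of what the source reports. "The series", "measured", "known", "first", "only" and "open" are said of these compounds alone.

Measured so far in an ADME assay on HEK293 cells (Homo sapiens) for cytotoxicity, read by CellTiter-Glo, with a stated time of 72 h; on this read-out lower numbers stand for an effect already at smaller amounts and higher numbers for an effect only at larger amounts of compound:
- Compound 1 `C/C1=C/C2=C[C@H](C)C[C@@]23O[C@]2(CC(C)(C)C[C@@H]2[C@@]1(O)C(F)(F)F)[C@@H](C)C3=O`: 26000 nM
- Compound 2 `CC1=C2CC(C)(C)/C=C/C(=O)/C(C)=C\C3=C[C@H](C)C[C@]3(O2)[C@@]1(O)C(F)(F)F`: 26000 nM

On these numbers, compound 2 stands level with compound 1, and the two values lie within the scatter of each other. Compound 3 `CC1=C2CC(C)(C)/C=C/C(=O)/C(C)=C\C3=C[C@H](C)C[C@]3(O2)[C@@]1(O)C#N` has not yet been measured. It departs from compound 2 in one place: cyano in place of trifluoromethyl on a saturated ring carbon. Cyano takes the place of trifluoromethyl on a saturated ring carbon of a five-membered non-aromatic ring with 1 oxygen, part of a fused or bridged system of three rings.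

For the measured compounds named here, no pair of measured compounds differs in one place only, so the data offer no measured step to guide this change. Going by the values given here, the only anchor is compound 2 at 26000 nM. In this assay, a step no larger than the scatter is therefore expected, with a slight lean towards lower numbers. The expected change is a 1.3-fold lower number from compound 2 to compound 3 (0.11 log units; within the scatter). For compound 3 the estimated value is 20000 nM, with an expected range of 7000 nM to 50000 nM.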

Compound 3, half-maximal effective concentration: 26000 nM
Compound 3: middle estimate off by 1.3-fold (0.11 log units), on the low side; the range from low to high includes it.
By their numbers in this assay, from the lowest: compounds 1, 2 and 3 (each within the scatter of the next).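

In this assay, putting cyano in place of trifluoromethyl on a saturated ring carbon of the five-membered non-aromatic ring with 1 oxygen brings no change at the digits printed from compound 2 to compound 3 (within the scatter). For the compounds shown here, this is the first step that can be read at a single place, and it shows that, on this read-out, the two groups cannot be told apart at this position on the core of compound 2, even though the entering cyano has 2 heavy atoms and 1 hydrogen-bond acceptor and the leaving trifluoromethyl has 4 heavy atoms and 0 hydrogen-bond acceptors. No measurement at hand bears on why the read-out responds in this way.

The compounds shown leave open whether an amine, a carboxylic acid or a longer chain on this same ring carbon would also stay within the scatter of compound 2. They also leave open whether cyano in place of trifluoromethyl on the core of compound 1 would give the same result in this assay.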